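Losing the dimethylamino group from compound 3

The source may report more compounds than this note shows. Statements on the series, on what has been measured and on what is new or still open speak of the compounds shown alone.

In a functional assay on HCT-116 cells (Homo sapiens) for cytotoxicity (on this read-out higher numbers stand for weaker inhibition and lower numbers for stronger inhibition), compound 1 `COc1cc(N2CCC(C(=O)N3CCC(N(C)C)C3)CC2)ccc1Nc1nc(NC2CCCCC2)c2nc[nH]c2n1` gives 58 nM, compound 2 `COc1cc(N2CCC(C(=O)N3CCOCC3)CC2)ccc1Nc1nc(NC2CCCCC2)c2nc[nH]c2n1` gives 50 nM and compound 3 `COc1cc(N2CCC(CC(=O)N3CCC(N(C)C)C3)CC2)ccc1Nc1nc(NC2CCCCC2)c2nc[nH]c2n1` gives 59 nM, so compound 3 stands within the scatter of both. Compound 4 `COc1cc(N2CCC(CC(=O)N3CCCC3)CC2)ccc1Nc1nc(NC2CCCCC2)c2nc[nH]c2n1` differs from compound 3 by hydrogen in place of dimethylamino on a saturated ring carbon. Within the data shown here, no measured step makes exactly this change. The nearest is the exchange of 3-(dimethylamino)pyrrolidin-1-yl for morpholin-4-yl, a 1.2-fold lower number from compound 1 to compound 2 (0.06 log units; within the scatter), and the steps of a 1.2-fold higher number from compound 2 to compound 3 (0.07 log units; within the scatter) and a 1.0-fold higher number from compound 1 to compound 3 (0.01 log units; within the scatter) are equally small. Nothing beyond the scatter is therefore expected, and the estimated step is a 1.1-fold lower number from compound 3 to compound 4 (0.03 log units; within the scatter). The expected value for compound 4 is 55 nM, with an estimated range of 27 nM to 115 nM.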

Compound 4, half-maximal inhibitory concentration: 15 nM
Compound 4: the middle estimate sits 3.7-fold (0.56 log units) above what was measured; the whole stated range lies above it.
By their numbers in this assay, from the lowest: compound 4; then compounds 2, 1 and 3 (each within the scatter of the next).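

Unlike the steps among compound 1, compound 2 and compound 3, all within the scatter, removing dimethylamino from this saturated ring carbon moves the number in this assay beyond the scatter, with a 3.9-fold lower number from compound 3 to compound 4 (0.59 log units; beyond the scatter). The unsubstituted pyrrolidin-1-yl amide also stands apart from the other two compounds, with a 3.3-fold lower number from compound 2 to compound 4 (0.52 log units; beyond the scatter) and a 3.9-fold lower number from compound 1 to compound 4 (0.59 log units; beyond the scatter). No evidence is available to explain this step. As far as these compounds go, what a hydroxyl or methyl group on that ring carbon would do remains open, as does whether a piperidin-1-yl amide would match compound 4.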